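Lengthening the Chain Linking Two Chloro-Substituted Heteroaromatics

A few compounds are considered here, and "the series" means these few. Any claim that something is new, unique, unknown or untested is made for them only; others in the source may bear on it.

Of the compounds shown here, three have been measured in a physicochemical assay for lipophilicity, read by HPLC, in phosphate buffer, measured as octanol-water partition, with a stated time of 24 h, at pH 7.4; a lower number here means a more polar compound, a higher number a more lipophilic compound. Compound 1 `Clc1ccc2c(NCCCCNc3nccc(Cl)n3)ccnc2c1` gives 0.742, and compound 2 `Clc1ccc2c(NCCNc3ccnc(Cl)n3)ccnc2c1` gives 0.489. Compound 3 `Clc1ccc2c(NCCCCCCCCNc3nccc(Cl)n3)ccnc2c1` gives 1.51, the highest of the three numbers; compound 1 lies closest to it and compound 2 furthest, both beyond the scatter. Compound 4 `Clc1ccc2c(NCCCCCCCCCCNc3nccc(Cl)n3)ccnc2c1` is not yet measured. It differs from compound 3 in one place: 2-((4-chloropyrimidin-2-yl)amino)ethyl in place of (4-chloropyrimidin-2-yl)amino on a saturated chain carbon, eight bonds along the chain from a nitrogen on an aromatic ring. Because compound 3 stands at 1.51 while the shorter compound 1 stands at 0.742, the longer chain of compound 4 is expected to push the number higher, with a modest step of a number 0.39 log units higher from compound 3 to compound 4 (beyond the scatter) likely just beyond the scatter. The estimate for compound 4 in this assay is 1.9, between 1.5 and 2.4.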

Compound 4, distribution coefficient: 1.99
Estimate against measurement, compound 4: 0.09 log units below, and the stated range covers the measured number.
By their numbers in this assay, from the lowest: compounds 2 and 1 (each within the scatter of the next); then compound 3; then compound 4.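

Within the data shown here, replacing (4-chloropyrimidin-2-yl)amino with 2-((4-chloropyrimidin-2-yl)amino)ethyl on this saturated chain carbon gives the first single-place comparison in this assay (a number 0.48 log units higher from compound 3 to compound 4 (beyond the scatter)). Both groups carry one six-membered aromatic ring with 2 hetero atoms, the same hydrogen-bond donor and acceptor counts and no net charge, so the difference lies in the chain alone. No supporting measurement explains the size of this step.

On these data alone, whether a longer chain would move the number further remains open. So does the effect of an amine within the chain.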